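The source may hold more compounds than are shown below. What is called first, only, known or untested is meant among the compounds shown, and "the series" means these compounds.

In a functional assay on the whole organism with Rattus norvegicus as the target (a higher number here means that more compound is needed for the effect, a lower number that less compound is needed), compound 1 `CCOC(=O)C(=O)Nc1cccc(N(C)C)c1C#N` gives 4.2 mg/kg, compound 2 `CCOC(=O)C(=O)Nc1cccc(NC)c1C#N` gives 0.1 mg/kg, and compound 3 `CCNc1cccc(NC(=O)C(=O)OCC)c1C#N` gives 0.03 mg/kg, the lowest of the three numbers. Compound 4 `CCCNc1cccc(NC(=O)C(=O)OCC)c1C#N` turns the ethylamino group of compound 3 into propylamino: methyl in place of hydrogen on a saturated chain carbon, two bonds along the chain from a nitrogen on an aromatic ring. Within the data shown here, the closest precedent is the modest 3.3-fold lower number from compound 2 to compound 3 (0.52 log units; beyond the scatter), which also lengthens the chain. The large 42-fold lower number from compound 1 to compound 2 (1.62 log units; beyond the scatter) and a 140-fold lower number from compound 1 to compound 3 (2.15 log units; beyond the scatter) both start from dimethylamino and bear less directly. One lengthening shows no trend. No step beyond the scatter is expected, and the estimate is a 1.3-fold higher number from compound 3 to compound 4 (0.12 log units; within the scatter). For compound 4 the expected value is 0.04 mg/kg, within an estimated range of 0.01 mg/kg to 0.2 mg/kg.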

Compound 4, dose for half-maximal effect: 0.7 mg/kg
For compound 4 the middle estimate is 18-fold (1.24 log units) below the measured one; measured number above the stated range.
By their numbers in this assay, from the lowest: compound 3; then compound 2; then compound 4; then compound 1.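

In this assay the added methyl at this place, two bonds along the chain from the nitrogen, gives a 23-fold higher number from compound 3 to compound 4 (1.37 log units; beyond the scatter) and so reverses the fall in the number seen on going from methylamino to ethylamino. Propylamino also loses out to methylamino, with a 7.0-fold higher number from compound 2 to compound 4 (0.85 log units; beyond the scatter) and yet still beats dimethylamino, with a 6.0-fold lower number from compound 1 to compound 4 (0.78 log units; beyond the scatter) as that step. Ethylamino alone thus holds the lowest number in this short series, and nothing available bears on why the added methyl has this effect. On these data alone, whether butyl or branched isopropylamino would raise the number further stays open.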